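The compounds below may be only part of what the source reports. "The series", "measured", "known", "first", "only" and "open" are said of these compounds alone.

- compound 1 `COc1ccc(Nc2nc3ccccc3nc2S(=O)(=O)c2ccc(OC)cc2)cc1`: 1190 nM
- compound 2 `COc1ccc(S(=O)(=O)c2nc3ccccc3nc2Nc2cccc(N)c2)cc1`: 1490 nM

In a functional assay on HL-60 cells (Homo sapiens) for cytotoxicity, read by MTT assay, with a stated time of 72 h (on this read-out higher numbers stand for weaker inhibition and lower numbers for stronger inhibition), compound 2 gives 1490 nM and compound 1 gives 1190 nM, so the two stand within the scatter of each other. Compound 3 `Nc1cccc(Nc2nc3ccccc3nc2S(=O)(=O)c2ccc(Br)cc2)c1` differs from compound 2 on the other aryl group: bromo in place of methoxy on an aromatic carbon. Among the compounds with values here, the only measured step, a 1.3-fold higher number from compound 1 to compound 2 (0.10 log units; within the scatter), lies elsewhere in the molecule, so it offers only indirect guidance, and no measured step tests this swap. No shift beyond the scatter is therefore expected, and the estimate means a 1.1-fold lower number from compound 2 to compound 3 (0.06 log units; within the scatter) as the expected step. Compound 3 is expected at 1300 nM with an estimated range from 450 nM to 3800 nM.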

Compound 3, half-maximal inhibitory concentration: 1370 nM
For compound 3 the middle estimate is 1.1-fold (0.02 log units) below the measured one; the measured number falls inside the stated range.
By their numbers in this assay, from the lowest: compounds 1, 3 and 2 (each within the scatter of the next).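

Within the data shown here, compound 1 and compound 2 differ only in the aryl group on the nitrogen, so this is the first change on the other aryl group. In this assay, going from 4-methoxyphenyl to 4-bromophenyl gives a 1.1-fold lower number from compound 2 to compound 3 (0.04 log units; within the scatter) and so no shift beyond the scatter at this position. No measurement on hand explains this result.

Going by these compounds, whether a different group here, such as an amine or a carboxylic acid, would shift the number remains open. Also open, on these data alone, is whether bromo in place of methoxy would read the same with another group on the nitrogen.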